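This account rests on a few compounds, and the source may have more. Where it says the series, first, only, none or still open, it means among the compounds named here.

In a functional assay on HepG2 cells (Homo sapiens) for antiproliferative activity, read by MTT assay, with a stated time of 24 h (on this read-out higher numbers stand for weaker inhibition and lower numbers for stronger inhibition), three compounds sharing one core have been measured. Compound 1 `Brc1cccc(Cc2nnc(Cn3nnc4ccccc43)o2)c1`, which carries bromo on an aromatic carbon, gives 398000 nM. Compound 2 `Clc1cccc(Cc2nnc(Cn3nnc4ccccc43)o2)c1`, with chloro there, gives 401000 nM. Compound 3 `COc1cccc(Cc2nnc(Cn3nnc4ccccc43)o2)c1`, with methoxy there, gives 350000 nM, which lies within the usual scatter of both other values, so the three cannot be ranked.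

Compound 4 `COc1ccc(Cc2nnc(Cn3nnc4ccccc43)o2)cc1` has the same atoms as compound 3, joined differently: 4-methoxyphenyl in place of 3-methoxyphenyl on a saturated chain carbon bound to an aromatic carbon. In words, 4-methoxyphenyl stands in place of 3-methoxyphenyl on a saturated chain carbon bound to an aromatic carbon.

Within the data shown here, no measured step moves a group to another carbon of the ring, so the evidence is indirect. The closest guides are the group swaps: a 1.0-fold higher number from compound 1 to compound 2 (0.00 log units; within the scatter), a 1.1-fold lower number from compound 1 to compound 3 (0.06 log units; within the scatter) and a 1.1-fold lower number from compound 2 to compound 3 (0.06 log units; within the scatter). All three stay within the scatter, so no change beyond the scatter is expected here, and neither direction is favoured. The expected step is a 1.1-fold higher number from compound 3 to compound 4 (0.02 log units; within the scatter). Compound 4 is estimated at 370000 nM, with an expected range from 190000 nM to 650000 nM.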

Compound 4, half-maximal inhibitory concentration: 357000 nM
For compound 4 the middle estimate is 1.0-fold (0.02 log units) above the measured one; low and high end bracket the measured number.
By their numbers in this assay, from the lowest: compounds 3, 4, 1 and 2 (each within the scatter of the next).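

In this assay, among these compounds, 4-methoxyphenyl in place of 3-methoxyphenyl gives a 1.0-fold higher number from compound 3 to compound 4 (0.01 log units; within the scatter) and so provides the first direct look at two placements of one group on this ring, with no difference beyond the scatter. Against the other two compounds, 4-methoxyphenyl in place of 3-chlorophenyl gives a 1.1-fold lower number from compound 2 to compound 4 (0.05 log units; within the scatter) while 4-methoxyphenyl in place of 3-bromophenyl gives a 1.1-fold lower number from compound 1 to compound 4 (0.05 log units; within the scatter) and neither step leaves the scatter, so all four compounds remain unranked. No measurement is available that could account for how closely these numbers agree.

From the compounds shown here alone, it remains open whether a group of another kind on this ring, such as an amine or a carboxylic acid, would give a number beyond the scatter. Also open, going by these compounds, is what a longer chain in place of the saturated chain carbon bound to an aromatic carbon would do.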